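A few compounds are considered here, and "the series" means these few. Any claim that something is new, unique, unknown or untested is made for them only; others in the source may bear on it.

Compound 1 `O=C(CCCCCCc1ccccc1)c1ncc(-c2ccccc2C(=O)C(F)(F)F)o1`: in an assay (Rattus norvegicus) for inhibition of Fatty-acid amide hydrolase 1 (Homo sapiens) (a lower number here means a stronger inhibitor, a higher number a weaker inhibitor), compound 1 gives 5000 nM.
Compound 2 `O=C(O)c1ccc(-c2cnc(C(=O)CCCCCCc3ccccc3)o2)cc1`: in this assay compound 2 gives 60 nM.
Compound 3 `CN(C)C(=O)c1cnc(C(=O)CCCCCCc2ccccc2)o1`: in this assay compound 3 gives 2 nM.

Among these three numbers compound 2 stands second highest: its nearest neighbour is compound 3, with a lower number, and the furthest is compound 1, with a higher number. The step of interest leads to compound 4 `O=C(CCCCCCc1ccccc1)c1ncc(C(=O)N2CCOCC2)o1`, which is not yet measured. Compared with compound 2, ((morpholin-4-yl)carbonyl in place of 4-carboxyphenyl on an aromatic carbon). Within the data shown here, only one measured step bears on this change: a 30-fold lower number from compound 2 to compound 3 (1.48 log units; beyond the scatter), where the same 4-carboxyphenyl was exchanged for dimethylcarbamoyl, a tertiary amide. The (morpholin-4-yl)carbonyl that enters compound 4 is also a tertiary amide, so a step of similar size and in the same direction, toward a lower number, is expected in this assay. For compound 4 the estimate is 3 nM, with a range from 1 nM to 15 nM. The expected step is therefore a 20-fold lower number from compound 2 to compound 4 (1.30 log units; beyond the scatter).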

Compound 4, inhibition constant: 24 nM
Compound 4: the middle estimate sits 8.0-fold (0.90 log units) below what was measured; the whole stated range lies below it.
By their numbers in this assay, from the lowest: compound 3; then compound 4; then compound 2; then compound 1.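

In this assay, the gain from exchanging 4-carboxyphenyl for a tertiary amide at this position persists with morpholine but shrinks to a 2.5-fold lower number from compound 2 to compound 4 (0.40 log units; beyond the scatter). The new finding is that the amine part of the amide matters, since morpholin-4-yl in place of dimethylamino on the same carbonyl carbon gives a 12-fold higher number from compound 3 to compound 4 (1.08 log units; beyond the scatter), so these two tertiary amides are not interchangeable here. Nothing available explains this difference between the two amides.

As far as these compounds go, it remains open whether the weaker result of compound 4 goes with the ring itself or with its oxygen, a question that piperidin-1-yl on the same carbonyl could separate. Also open, from the compounds shown here alone, is how a secondary amide, which keeps an amide hydrogen, would compare with the dimethylcarbamoyl group of compound 3.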